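Adding a Nitro Group to Compound 1

The source may report more compounds than this note shows. Statements on the series, on what has been measured and on what is new or still open speak of the compounds shown alone.

Measured compounds:
Compound 1, `COc1ccc(C2C(OC(C)=O)C(=O)N2c2cc(OC)c(OC)c(OC)c2)cc1`: 251 nM
Compound 2, `COc1ccc(C2C(O)C(=O)N2c2cc(OC)c(OC)c(OC)c2)cc1`: 33 nM
Compound 3, `COc1ccc(N2C(=O)C(O)C2c2cc(OC)c(OC)c(OC)c2)cc1`: a limit of the assay, > 1000 nM

All three were tested in a functional assay on IMR-32 cells (Homo sapiens) for cytotoxicity; a higher number here means a weaker inhibitor, a lower number a stronger inhibitor. Compound 1 has the highest of the two numbers recorded; its nearest neighbour is compound 2, and the change from the acetate of compound 1 to the free hydroxyl of compound 2 gives a 7.6-fold lower number from compound 1 to compound 2 (0.88 log units; beyond the scatter). For compound 3 the result is only a limit, (the limit of > 1000 nM in this assay, at which 1 of the 3 values shown sits), so no number is known for it.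

Compound 4, `COc1ccc(C2C(OC(C)=O)C(=O)N2c2cc(OC)c(OC)c(OC)c2)cc1[N+](=O)[O-]`, differs from compound 1 by nitro in place of hydrogen on an aromatic carbon, sitting ortho to a methoxy group and meta to a large group. Among the measured compounds shown here, none of the measured steps involves a change on an aromatic ring; the only measured step, from compound 1 to compound 2, concerns the oxygen on the saturated carbon and does not bear on this change. With nothing to point either way, the expected step of a 1.0-fold lower number from compound 1 to compound 4 (0.00 log units; within the scatter) is none beyond the scatter. Compound 4 is therefore estimated at 250 nM, within 80 nM to 800 nM.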

Compound 4, half-maximal inhibitory concentration: 123 nM
Beside the measured number, compound 4's estimate is 2.0-fold (0.31 log units) above it; low and high end bracket the measured number.
By their numbers in this assay, from the lowest: compound 2; then compound 4; then compound 1. At a limit, above all of these: compound 3.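

In this assay, nitro in place of hydrogen on an aromatic carbon, ortho to a methoxy group and meta to a large group, gives a 2.0-fold lower number from compound 1 to compound 4 (0.31 log units; beyond the scatter). Among the compounds shown here, this is the first measured change on an aromatic ring, and it shows that this position can take a group of 3 heavy atoms with a modest drop in the number rather than a rise. Nothing given here explains why the number fell.

As far as these compounds go, it remains open whether this step belongs to nitro itself, or whether an amine or a carboxylic acid on the same carbon would move the number in the same direction. Also open, from the compounds shown here alone, is whether nitro would lower the number further on compound 2, whose free hydroxyl already gives 33 nM.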